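Aryl change on the sulfonyl with only limits so far

The source may hold more compounds than are shown below. What is called first, only, known or untested is meant among the compounds shown, and "the series" means these compounds.

In an ADME assay on HCT-116 cells (Homo sapiens) for cytotoxicity, read by CellTiter-Glo, with a stated time of 72 h (on this read-out higher numbers stand for weaker inhibition and lower numbers for stronger inhibition), compound 1 (`COc1cccc(S(=O)(=O)N2CCC(N3CCC(C)CC3)CC2)c1`) gives > 5000 nM as a limit of the assay and not a number.

Compound 2 (`CC1CCN(C2CCN(S(=O)(=O)c3cccc(Br)c3)CC2)CC1`) gives > 5000 nM and this too is only a limit.

Going by the values given here, compound 2 therefore has no number to stand on, and the series sits at the limit of > 5000 nM in this assay, at which 2 of the 2 values shown sit, as its only shared reading.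

The next change leads to compound 3 (`CC1CCN(C2CCN(S(=O)(=O)c3ccc(Cl)cc3Cl)CC2)CC1`), with 2,4-dichlorophenyl in place of 3-bromophenyl on a sulfonyl sulfur in full.

Among the compounds with values here, the only measured step bearing on it is a step that the two limits leave unreadable from compound 1 to compound 2 and it offers no size to carry over, so no direction can be argued.

The estimated step in this assay is a step that the limit leaves unreadable from compound 2 to compound 3 and nothing beyond the scatter is expected.

Compound 3 is expected at 7000 nM within an estimated range of 2500 nM to 20000 nM in this reading.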

Compound 3, half-maximal inhibitory concentration: > 5000 nM
Compound 3: a limit, no number; the forecaster's own chance of this, stated with the estimate: 75%; the middle value is on the limit's open side.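

Compound 3 is again a limit of the assay and not a number, so no step among compound 1, compound 2 and compound 3 can be read: the limit of > 5000 nM in this assay, at which 3 of the 3 values shown sit.

The compounds shown leave open whether any aryl group on the sulfonyl sulfur gives a readable number in this assay.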